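Shortening a Butyl Chain to Isopropyl in a Cytotoxicity Screen

A few compounds are considered here, and "the series" means these few. Any claim that something is new, unique, unknown or untested is made for them only; others in the source may bear on it.

Measured in a functional assay on ACHN cells (Homo sapiens) for cytotoxicity, read by sulforhodamine B assay, tested at 10 uM; on this read-out lower numbers stand for less inhibition and higher numbers for more inhibition at the one concentration tested (going by the name of the read-out):

Compound 1 `CCCCc1ccc(-c2cc(-c3cn([C@H]4C[C@H](OC(C)=O)[C@@H](COC(C)=O)O4)c(=O)[nH]c3=O)on2)cc1`: 80.5%
Compound 2 `CCCCCCCCc1cc(-c2cn([C@H]3C[C@H](O)[C@@H](CO)O3)c(=O)[nH]c2=O)on1`: 95.6%
Compound 3 `O=c1[nH]c(=O)n([C@H]2C[C@H](O)[C@@H](CO)O2)cc1-c1cn(Cc2ccccc2)nn1`: 98.7%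

Compound 1 stands lowest of these three numbers. Compound 2 lies above it by a gap beyond the usual scatter, and compound 3 lies above it by a somewhat larger gap, also beyond the scatter.

Compound 4 `CC(=O)OC[C@H]1O[C@@H](n2cc(-c3cc(-c4ccc(C(C)C)cc4)no3)c(=O)[nH]c2=O)C[C@@H]1OC(C)=O` has not yet been measured. It differs from compound 1 in one place: isopropyl in place of butyl on an aromatic carbon. Among the compounds with values here, no two measured compounds differ by such a change alone, so there is no measured step to lean on. The expectation is that this change leaves the read-out in this assay close to where compound 1 has it, with an expected step of a number 2.5 percentage points lower from compound 1 to compound 4 (within the scatter) that stays within the scatter. Compound 4 is therefore estimated at 78%, with a likely range from 62% to 92%.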

Compound 4, a percentage reported as inhibition, at one concentration (the size of the read-out at that concentration, not a potency): 90.1%
For compound 4 the middle estimate is 12.1 percentage points below the measured one; measured number inside the range.
By their numbers in this assay, from the lowest: compounds 1, 4, 2 and 3 (each within the scatter of the next, the first and the last beyond it).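

In this assay, within the data shown here, the change from 4-butylphenyl to 4-isopropylphenyl gives the first measured step at this position, a number 9.6 percentage points higher from compound 1 to compound 4 (within the scatter) on the core of compound 1. Butyl and isopropyl therefore cannot be told apart here, on an aromatic carbon para to a large group. Nothing on hand explains this step.

As far as these compounds go, whether a methyl group, an amine or a carboxylic acid at this place would stay within the same scatter remains open. Each number also comes from one concentration, so none of them gives a potency.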